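The source may report more compounds than this note shows. Statements on the series, on what has been measured and on what is new or still open speak of the compounds shown alone.

Compound 1 `O=C(/C=C/c1ccc(/C=C/C(=O)c2ccc3ccccc3c2)o1)NO`: 2220 nM
Compound 2 `O=C(/C=C/c1ccc(/C=C/C(=O)c2ccccc2)o1)NO`: 2890 nM
Compound 3 `COc1ccc2cc(C(=O)/C=C/c3ccc(/C=C/C(=O)NO)o3)ccc2c1`: 2060 nM

In a functional assay on HCT-116 cells (Homo sapiens) for antiproliferative activity, read by MTT assay, with a stated time of 48 h (on this read-out lower numbers stand for stronger inhibition and higher numbers for weaker inhibition), compound 2 gives 2890 nM. This value lies within the usual scatter of the values for both compound 1 and compound 3, so these compounds cannot be ranked against one another.

Compound 4 `Cc1ccc(C(=O)/C=C/c2ccc(/C=C/C(=O)NO)o2)cc1` is not yet measured. It differs from compound 2 in one place: methyl in place of hydrogen on an aromatic carbon. This is methyl in place of hydrogen on an aromatic carbon, which turns phenyl into 4-methylphenyl.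

Within the data shown here, only one measured step bears on this change: a 1.1-fold lower number from compound 1 to compound 3 (0.03 log units; within the scatter). There, methoxy in place of hydrogen on an aromatic carbon made no difference beyond the scatter. Among the measured compounds shown here, it involves a different group and a different pair of compounds, so it is only a loose guide, and no measured step shows the methyl change itself.

No shift beyond the scatter is therefore expected, and the estimated step is a 1.2-fold lower number from compound 2 to compound 4 (0.06 log units; within the scatter). Compound 4 is expected at 2500 nM, with an estimated range of 1300 nM to 4800 nM.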

Compound 4, half-maximal inhibitory concentration: 540 nM
Compound 4: the middle estimate sits 4.6-fold (0.67 log units) above what was measured; measured number below the stated range.
By their numbers in this assay, from the lowest: compound 4; then compounds 3, 1 and 2 (each within the scatter of the next).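

In this assay the step is a 5.4-fold lower number from compound 2 to compound 4 (0.73 log units; beyond the scatter) and lies beyond the scatter, so this is the first change among these compounds with a clear effect on the number. A single methyl, placed on the six-membered aromatic ring para to a large group to turn phenyl into 4-methylphenyl, is enough to produce this step, whereas the methoxy change, a 1.1-fold lower number from compound 1 to compound 3 (0.03 log units; within the scatter) on a different pair, stayed within the scatter. Nothing available here explains why this small change matters.

On these data alone, it remains open whether this step is specific to methyl: an ethyl group, a chlorine atom or an amine at the same place would test that. As far as these compounds go, it is also open whether a methyl group would give a similar step on compound 1.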